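The compounds below may be only part of what the source reports. "The series", "measured", "known", "first", "only" and "open" are said of these compounds alone.

Values in a functional assay on HCT-116 cells (Homo sapiens) for antiproliferative activity, read by MTT assay, with a stated time of 72 h (on this read-out higher numbers stand for weaker inhibition and lower numbers for stronger inhibition), as measured:
- compound 1 `N#Cc1cccc(Nc2ccc3c(c2)S(=O)(=O)C=C3)c1` gives > 10000 nM (a limit of the assay, not a number)
- compound 2 `O=S1(=O)C=Cc2ccc(Nc3cccc(OC(F)(F)F)c3)cc21` gives 1980 nM
- compound 3 `O=S1(=O)C=Cc2cccc(Nc3ccc(C(F)(F)F)cc3)c21` gives 1440 nM

For the measured compounds named here, compound 3 at 1440 nM and compound 2 at 1980 nM lie within the scatter of each other, and they are the only two true numbers. Compound 1 stands at a limit.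

Compound 4 `COc1ccc(Nc2cccc3c2S(=O)(=O)C=C3)cc1` keeps the scaffold of compound 3 and has methoxy in place of trifluoromethyl on an aromatic carbon, para to a large group (methoxy in place of trifluoromethyl on an aromatic carbon).

Going by the values given here, only one measured step bears on this, and only indirectly: an at least 5.0-fold lower number from compound 1 to compound 2 (0.70 log units; beyond the scatter). From the compounds shown here alone, that exchange, trifluoromethoxy in place of cyano, shows that one substituent change can move the number beyond the scatter, but its full size is unknown given (the limit of > 10000 nM in this assay, at which 1 of the 3 values shown sits). Neither group of the present exchange appears in that step. In this assay a small step towards a higher number is therefore expected, probably not clearing the scatter.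

The estimated step is a 1.7-fold higher number from compound 3 to compound 4 (0.24 log units; within the scatter).

Compound 4 is expected at 2500 nM, with an estimated range of 700 nM to 10000 nM.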

Compound 4, half-maximal inhibitory concentration: 1990 nM
Compound 4: the middle estimate sits 1.3-fold (0.10 log units) above what was measured; the range from low to high includes it.
By their numbers in this assay, from the lowest: compounds 3, 2 and 4 (each within the scatter of the next). At a limit, above all of these: compound 1.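

In this assay, the exchange of trifluoromethyl for methoxy, para to a large group, gives a 1.4-fold higher number from compound 3 to compound 4 (0.14 log units; within the scatter). For the compounds shown here, this is the first step with a true number at both ends, and it shows that these two groups are not separated at this position, even though they differ in heavy atoms and hydrogen-bond acceptors. The only earlier step cannot supply a full size for comparison: the limit of > 10000 nM in this assay, at which 1 of the 4 values shown sits.

From the compounds shown here alone, whether any group at this position can move the number beyond the scatter remains open, for example an amine, a carboxylic acid or a longer chain. Also open, going by these compounds, is whether the same exchange would stay within the scatter at another place on the ring.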